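Hydrogen to Hydroxy: An Expected Gain in Solubility

The source may report more compounds than this note shows. Statements on the series, on what has been measured and on what is new or still open speak of the compounds shown alone.

Of the compounds shown here, three have so far been measured in a physicochemical assay for solubility, read by nephelometry, measured as kinetic solubility, at pH 2.0; a higher number here means a more soluble compound, a lower number a less soluble compound. Compound 1 `NCc1csc(NC(=O)c2ccc(Cl)cc2)n1` sits at an assay limit rather than at a number: in this assay compound 1 gives > 100 ug/mL, which is the limit of > 100 ug/mL in this assay, at which 1 of the 3 values shown sits. Compound 3 `NCc1csc(NC(=O)c2cn(Cc3ccccc3)nn2)n1` gives 50 ug/mL in this assay. Compound 2 `Cc1csc(NC(=O)c2cc(C(C)(C)C)nn2Cc2ccccc2)n1` also sits at a limit and not at a number: in this assay compound 2 gives < 1.6 ug/mL, which is the limit of < 1.6 ug/mL in this assay, at which 1 of the 3 values shown sits. Compound 2 therefore stands at the low edge of what this assay can report, while the other two values stand at or toward the high end.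

Compound 4 `CC(C)(C)c1cc(C(=O)Nc2nc(CO)cs2)n(Cc2ccccc2)n1` differs from compound 2 in one place: hydroxy in place of hydrogen on a saturated chain carbon bound to an aromatic carbon. Among the measured compounds shown here, no pair of measured compounds shows this change, so its size cannot be read from the measured data. The step of an at least 3.1-fold higher number from compound 2 to compound 4 (0.49 log units; beyond the scatter) is expected to run upward and beyond the usual scatter, though not by a large margin. Compound 4 is estimated to give 5 ug/mL in this assay, with a range from 1.6 ug/mL to 20 ug/mL, and a real chance that only a limit is again reported.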

Compound 4, solubility: 12.5 ug/mL
Beside the measured number, compound 4's estimate is 2.5-fold (0.40 log units) below it, and the stated range covers the measured number.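

Hydroxy in place of hydrogen on a saturated chain carbon bound to an aromatic carbon now has a measured size in this assay: the step is an at least 7.8-fold higher number from compound 2 to compound 4 (0.89 log units; beyond the scatter) and is the first one read between compounds that differ in one place. Compound 4 gives a number of 12.5 ug/mL and not a limit, so methyl to hydroxymethyl takes this compound off the low edge of this assay. The step does not give the full size of the change. Compound 2 stands at a limit and not at a number: the limit of < 1.6 ug/mL in this assay, at which 1 of the 4 values shown sits.

The compounds shown leave open whether another group on this carbon, such as a methyl ether, a carboxylic acid or a longer chain, would give a step of like size. Among the compounds shown here, they also leave open whether this change runs the same way on another core, as only this one pair carries it.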